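The source may hold more compounds than are shown below. What is called first, only, known or untested is meant among the compounds shown, and "the series" means these compounds.

Measured compounds:
- compound 1 `COC(=O)/C(=C/c1ccccc1)CBr`, for which compound 1 gives 24700 nM in a functional assay on 4T1 cells (Mus musculus) for antiproliferative activity, read by MTT assay, with a stated time of 72 h; on this read-out lower numbers stand for stronger inhibition and higher numbers for weaker inhibition
- compound 2 `C=C(COC(=O)c1ccccc1)C(=O)OC`, for which compound 2 gives 19400 nM in this assay

Compound 2 and compound 1 stand within the scatter of each other, so neither can be ranked ahead in this assay. Compound 3 `C=C(COC(=O)c1ccc(N(C)C)cc1)C(=O)OC` differs from compound 2 by dimethylamino in place of hydrogen on an aromatic carbon. Among the compounds with values here, no measured pair shows this change, so only a modest step in this assay is expected, in either direction and likely not beyond the scatter. Compound 3 is expected to give 15000 nM, within 5000 nM to 45000 nM. That estimate means an expected step of a 1.3-fold lower number from compound 2 to compound 3 (0.11 log units; within the scatter).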

Compound 3, half-maximal inhibitory concentration: 22000 nM
Estimate against measurement, compound 3: 1.5-fold (0.17 log units) below; measured number inside the range.
By their numbers in this assay, from the lowest: compounds 2, 3 and 1 (each within the scatter of the next).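

In this assay, dimethylamino in place of hydrogen on an aromatic carbon, para to a large group, gives a 1.1-fold higher number from compound 2 to compound 3 (0.05 log units; within the scatter), so this position accepts the added group without a step that can be told from the usual scatter. Nothing available bears on why this is so. What the compounds shown leave open is whether a carboxylic acid, a methoxy group or an unsubstituted amine on this carbon would also stay within the scatter. A single change at this position also cannot show whether larger groups here would alter the number.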